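Ethoxy for methylsulfanyl on the shared core

This account rests on a few compounds, and the source may have more. Where it says the series, first, only, none or still open, it means among the compounds named here.

Among the compounds with values here, in a functional assay on HeLa cells (Homo sapiens) for antiproliferative activity, read by CCK-8 assay, with a stated time of 72 h (on this read-out higher numbers stand for weaker inhibition and lower numbers for stronger inhibition), compound 1 (`COc1ccc(-c2cncnc2-c2cc(OC)c(OC)c(OC)c2)cc1Cl`) gives 320 nM while compound 2 (`COc1cc(-c2ncncc2-c2ccc(SC)cc2)cc(OC)c1OC`) gives 220 nM and so stands within the scatter of the only other measured number. Compound 3 (`CCOc1ccc(-c2cncnc2-c2cc(OC)c(OC)c(OC)c2)cc1`) carries ethoxy in place of methylsulfanyl on an aromatic carbon. Within the data shown here, the one measured step bearing on this is a 1.5-fold lower number from compound 1 to compound 2 (0.16 log units; within the scatter) and it also exchanged a group on the same aromatic ring. It lies within the scatter, so no step beyond the scatter is expected in this assay and the estimated step is a 1.4-fold higher number from compound 2 to compound 3 (0.13 log units; within the scatter) in size. Compound 3 is therefore expected at 300 nM (estimated range 100 nM to 900 nM).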

Compound 3, half-maximal inhibitory concentration: 250 nM
Compound 3: the middle estimate sits 1.2-fold (0.08 log units) above what was measured; the range from low to high includes it.
By their numbers in this assay, from the lowest: compounds 2, 3 and 1 (each within the scatter of the next).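

In this assay the exchange of methylsulfanyl for ethoxy gives a 1.1-fold higher number from compound 2 to compound 3 (0.06 log units; within the scatter) and so shows that this place, para to a large group, takes either group without a step beyond the scatter. The exchange of 3-chloro-4-methoxyphenyl for 4-ethoxyphenyl gives a 1.3-fold lower number from compound 1 to compound 3 (0.11 log units; within the scatter) and thus adds a second step within the scatter on the same ring position. No supporting evidence is available to account for these results. Going by these compounds, whether an amine or a carboxylic acid at this place, or a longer chain, would also stay within the scatter remains open.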